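Triazole-linked chalcones: nitrophenyl ketone with a fluorobenzyl arm

The source may report more compounds than this note shows. Statements on the series, on what has been measured and on what is new or still open speak of the compounds shown alone.

Of the compounds shown here, two carry numbers so far. Compound 1 `O=C(/C=C/c1ccc(OCc2cn(Cc3cccc(F)c3)nn2)cc1)c1ccc(Br)cc1` bears a 3-fluorobenzyl group on the triazole and a bromophenyl ketone; in a functional assay on MCF7 cells (Homo sapiens) for inhibition, read by MTT assay, with a stated time of 48 h, tested at 10 uM (on this read-out lower numbers stand for less inhibition of growth and higher numbers for more inhibition of growth at the one concentration tested), compound 1 gives 42%. Compound 2 `O=C(/C=C/c1ccc(OCc2cn(Cc3ccccc3Br)nn2)cc1)c1ccc([N+](=O)[O-])cc1` bears a 2-bromobenzyl group on the triazole and a nitrophenyl ketone; in this assay compound 2 gives 43%. Compound 2 holds the upper of the two numbers, yet the gap to compound 1 is within the scatter, so the two measurements cannot be ranked against each other. Going by the values given here, no single-point step between measured compounds is available.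

Compound 3 `O=C(/C=C/c1ccc(OCc2cn(Cc3cccc(F)c3)nn2)cc1)c1ccc([N+](=O)[O-])cc1` is not yet measured. It differs from compound 2 by 3-fluorophenyl in place of 2-bromophenyl on a saturated chain carbon bound to an aromatic nitrogen, and keeps the nitrophenyl ketone. Compound 1 already carries the 3-fluorobenzyl arm and gives a number within the scatter of compound 2, so no step beyond the scatter is expected in this assay in either direction; the expected step is no change at the digits printed from compound 2 to compound 3 (within the scatter). Compound 3 is estimated at 43%, with a range from 28% to 58%.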

Compound 3, percent growth inhibition at one concentration: 30%
Compound 3: the middle estimate sits 13 percentage points above what was measured; the measured number falls inside the stated range.
By their numbers in this assay, from the lowest: compound 3; then compounds 1 and 2 (each within the scatter of the next).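

Going by these compounds alone, on a saturated chain carbon bound to an aromatic nitrogen, 3-fluorophenyl in place of 2-bromophenyl gives the first readable step at this position in this assay (a number 13 percentage points lower from compound 2 to compound 3 (beyond the scatter)), with the nitrophenyl ketone held constant. With the 3-fluorobenzyl arm held constant, nitro in place of bromo on an aromatic carbon also gives a readable step (a number 12 percentage points lower from compound 1 to compound 3 (beyond the scatter)), so in this small set the read-out responds to a change in either place, and both steps lead down to compound 3. No measurement at hand accounts for either step.

The arm step changes the halogen and its ring place together, so the compounds shown cannot assign it to either one, and they do not show whether the nitro step would hold with the 2-bromobenzyl arm. Also open, on these data alone, is how the read-out would respond to an unsubstituted benzyl arm on the triazole, or to an amine or a carboxylic acid in place of nitro on the ketone's phenyl ring.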